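Replacing cyclohexyl with butyl on a sulfonyl-bound chain carbon

This account rests on a few compounds, and the source may have more. Where it says the series, first, only, none or still open, it means among the compounds named here.

Compound 1 `O=S(=O)(/C=C/c1ccc(O)c(O)c1)CC1CCC1`: 8800 nM
Compound 2 `O=S(=O)(/C=C/c1ccc(O)c(O)c1)CCC1CCCCC1`: 9800 nM
Compound 3 `O=S(=O)(/C=C/c1ccc(O)c(O)c1)CC1CCCCC1`: 7500 nM

All three values come from a functional assay, read by fluorescence and spectrophotometry, with a stated time of 1 h; on this read-out higher numbers stand for an effect only at larger amounts of compound and lower numbers for an effect already at smaller amounts. Compound 3 gives 7500 nM, which cannot be told apart from the values of the other two compounds. Compound 4 `CCCCCS(=O)(=O)/C=C/c1ccc(O)c(O)c1` has not yet been measured. It differs from compound 3 in one place: butyl in place of cyclohexyl on a saturated chain carbon bound to a sulfonyl sulfur, with butyl in place of cyclohexyl on a saturated chain carbon bound to a sulfonyl sulfur.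

Among the measured compounds shown here, three measured steps bear on this change, and all of them alter the group at that same place. They are a 1.2-fold lower number from compound 1 to compound 3 (0.07 log units; within the scatter), a 1.1-fold higher number from compound 1 to compound 2 (0.05 log units; within the scatter) and a 1.3-fold lower number from compound 2 to compound 3 (0.12 log units; within the scatter). Each stays within the scatter, so compounds 1, 2 and 3 show no trend with the group carried there. For the measured compounds named here, all three of these groups contain a ring, however, and no measured compound has an open chain at this place. The evidence for butyl is therefore indirect, and the range has to stay wide.

In this assay, the expected result is no change beyond the scatter, in either direction. The estimated step is a 1.1-fold higher number from compound 3 to compound 4 (0.05 log units; within the scatter). For compound 4 the estimated value is 8500 nM. The expected range for compound 4 runs from 4000 nM to 16000 nM.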

Compound 4, half-maximal effective concentration: 8100 nM
Estimate against measurement, compound 4: 1.0-fold (0.02 log units) above; low and high end bracket the measured number.
By their numbers in this assay, from the lowest: compounds 3, 4, 1 and 2 (each within the scatter of the next).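

In this assay, the open butyl chain on a saturated chain carbon bound to a sulfonyl sulfur reads the same as the groups with a ring, with a 1.1-fold higher number from compound 3 to compound 4 (0.03 log units; within the scatter) and a 1.1-fold lower number from compound 1 to compound 4 (0.04 log units; within the scatter) and also a 1.2-fold lower number from compound 2 to compound 4 (0.08 log units; within the scatter) all staying inside the usual scatter. Compounds 1, 2 and 3 all carry a ring at this place, so they could not show whether the number holds without one; compound 4 shows that, across these four compounds, taking away the ring leaves the value where it was. No measurement here accounts for this flat result.

All four groups at this place are made of carbon only, and nothing here tells whether an amine or a carboxylic acid there would stay within the scatter of these compounds. From the compounds shown here alone, a chain longer than butyl, or one as short as methyl, is equally open, as is whether any group at this place can move the number beyond the scatter at all.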